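The source may hold more compounds than are shown below. What is called first, only, known or untested is meant among the compounds shown, and "the series" means these compounds.

Compound 1 `CCc1ccc(-c2nc3ccccn3c2Sc2ccccc2)cc1`: 52100 nM
Compound 2 `c1ccc(Sc2c(-c3cccc4ccccc34)nc3ccccn23)cc1`: 33100 nM

Both values come from a functional assay on HeLa cells (Homo sapiens) for inhibition, read by MTT assay, with a stated time of 48 h; on this read-out lower numbers stand for stronger inhibition and higher numbers for weaker inhibition. Compound 1 stands level with compound 2, since the two numbers lie within the usual scatter of each other and give no ranking.

Compound 3 `N#Cc1ccc(-c2nc3ccccn3c2Sc2ccccc2)cc1` keeps the core of compound 1 and has cyano in place of ethyl on an aromatic carbon, para to a large group, so that 4-ethylphenyl becomes 4-cyanophenyl: cyano in place of ethyl on an aromatic carbon. It is still to be measured in this assay.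

Among the measured compounds shown here, no measured pair covers this change, so the data give no direct guide to its size or direction. For the measured compounds named here, the only anchors are compound 1 at 52100 nM and compound 2 at 33100 nM. On that basis, no shift beyond the scatter is expected, with only a slight lean towards a lower number. The expected step of a 1.2-fold lower number from compound 1 to compound 3 (0.09 log units; within the scatter) stays within the scatter. For compound 3 the estimated value is 42000 nM, with an expected range of 14000 nM to 110000 nM.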

Compound 3, half-maximal inhibitory concentration: 64200 nM
Compound 3: the middle estimate sits 1.5-fold (0.18 log units) below what was measured; low and high end bracket the measured number.
By their numbers in this assay, from the lowest: compounds 2, 1 and 3 (each within the scatter of the next).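

In this assay, among the compounds shown here, the change from 4-ethylphenyl to 4-cyanophenyl gives a 1.2-fold higher number from compound 1 to compound 3 (0.09 log units; within the scatter), the first direct reading of a single change at this position, on an aromatic carbon para to a large group. Both groups count 2 heavy atoms, while cyano adds a triple bond and a hydrogen-bond acceptor that ethyl lacks, and on this one pair that exchange produces no step beyond the scatter, so compound 1 and compound 3 stand level and neither group can be preferred. No measurement on these compounds bears on why the step is this small.

On these data alone, with only ethyl and cyano read at this position, it remains open whether any group placed there can move the number beyond the scatter, and an amine, a carboxylic acid or a longer chain such as butyl would be informative replacements. For the compounds shown here, the sulfur-linked phenyl shared by all three compounds also has no step of its own, so the contribution of that part of the series to the read-out remains unknown.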